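Dropping the same oxane group from two related cores

The compounds below may be only part of what the source reports. "The series", "measured", "known", "first", "only" and "open" are said of these compounds alone.

Measured compounds in a physicochemical assay for lipophilicity, read by HPLC, measured as chromatographic lipophilicity, at pH 7.4; a higher number here means a more lipophilic compound, a lower number a more polar compound:
- Compound 1, `CCCCCCCC(=O)NCCCN1C[C@H](C)C[C@@](C)(O)[C@H](O[C@@H]2O[C@H](C)C[C@H](N(C)C)[C@H]2O)[C@@H](C)[C@H](O[C@H]2C[C@@](C)(OC)[C@@H](O)[C@H](C)O2)[C@@H](C)C(=O)O[C@H](CC)[C@@](C)(O)[C@H](O)[C@H]1C`, gives 3.74.
- Compound 2, `CCCCCCCC(=O)NCCCN(C)[C@H]1C[C@@H](C)O[C@@H](O[C@@H]2[C@@H](C)[C@H](O[C@H]3C[C@@](C)(OC)[C@@H](O)[C@H](C)O3)[C@@H](C)C(=O)O[C@H](CC)[C@@](C)(O)[C@H](O)[C@@H](C)N(C)C[C@H](C)C[C@@]2(C)O)[C@@H]1O`, gives 3.74.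
- Compound 3, `CCCCCCCC(=O)NCCCN1C[C@H](C)C[C@@](C)(O)[C@H](O[C@@H]2O[C@H](C)C[C@H](N(C)C)[C@H]2O)[C@@H](C)[C@H](O)[C@@H](C)C(=O)O[C@H](CC)[C@@](C)(O)[C@H](O)[C@H]1C`, gives 3.08.

Compound 1 and compound 3 share a core and differ in one place: hydrogen in place of 5-hydroxy-4-methoxy-4,6-dimethyloxan-2-yl on an oxygen on a saturated carbon. In this assay this change gives a number 0.66 log units lower from compound 1 to compound 3 (beyond the scatter), a modest fall in lipophilicity when the oxane group is replaced by hydrogen.

Compound 2 is built from the same atoms as compound 1, joined differently; the difference between the two cores is not broken down here. In this assay compound 2 sits level with compound 1 at the digits given, and the two together stand highest of the three measured numbers, while compound 3 lies lower than both.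

Compound 4, `CCCCCCCC(=O)NCCCN(C)[C@H]1C[C@@H](C)O[C@@H](O[C@@H]2[C@@H](C)[C@H](O)[C@@H](C)C(=O)O[C@H](CC)[C@@](C)(O)[C@H](O)[C@@H](C)N(C)C[C@H](C)C[C@@]2(C)O)[C@@H]1O`, has not yet been measured. It relates to compound 2 as compound 3 relates to compound 1: hydrogen in place of 5-hydroxy-4-methoxy-4,6-dimethyloxan-2-yl on an oxygen on a saturated carbon. The place of the change is described in the same words for both pairs, so this is the same change on the second core.

Among the compounds with values here, with compound 2 starting level with compound 1, the step from compound 2 to compound 4 is expected to be a number 0.66 log units lower from compound 2 to compound 4 (beyond the scatter), resting on the step seen from compound 1 to compound 3, a number 0.66 log units lower from compound 1 to compound 3 (beyond the scatter), as the only measured example of this change. Compound 4 is therefore estimated at 3.08, with a range from 2.78 to 3.38.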

Compound 4, distribution coefficient: 4.84
Compound 4: the middle estimate sits 1.76 log units below what was measured; measured number outside the range, above it.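

In this assay the replacement of 5-hydroxy-4-methoxy-4,6-dimethyloxan-2-yl by hydrogen gives a number 1.10 log units higher from compound 2 to compound 4 (beyond the scatter) while the same replacement on the core of compound 1 gives a number 0.66 log units lower from compound 1 to compound 3 (beyond the scatter) and so the change runs in opposite directions on the two cores, each step beyond the scatter. This shows that in this series the step measured on one core could not be carried to the other, neither in size nor in sign, even though compound 1 and compound 2 start level and the change is described in the same words for both pairs. Within the data shown here, it does not show why the two cores part ways, nor which core gives the more typical step, since each core offers only one example of the change and nothing available here accounts for the reversal.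

On these data alone, with only these two pairs, it remains open whether a third core would follow compound 1 and compound 3, follow compound 2 and compound 4, or do neither. As far as these compounds go, it also remains open whether the reversal would persist if a longer chain or a carboxylic acid stood in place of the amide chain, or if a methyl group rather than hydrogen replaced the oxane group.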